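Metabolic stability of the 1,1-dioxothian-4-yl amide series

This account rests on a few compounds, and the source may have more. Where it says the series, first, only, none or still open, it means among the compounds named here.

Values so far in an ADME assay on microsomes from liver (Homo sapiens) for metabolic stability, with a stated time of 10 min (a higher number here means that more of the compound is left, a lower number that less of the compound is left), for each compound
- compound 1 `C[C@]1(C(=O)N2CC[C@](c3ccc(C(F)(C(F)(F)F)C(F)(F)F)cc3)(S(=O)(=O)c3ccc(F)cc3)C2)CC[C@H](C(=O)O)CC1` gives 80% remaining
- compound 2 `CS(=O)(=O)C1CCC(C(=O)N2CC[C@](c3ccc(C(F)(C(F)(F)F)C(F)(F)F)cc3)(S(=O)(=O)c3ccc(F)cc3)C2)CC1` gives 88%; 100% (2 entries) remaining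
- compound 3 `O=C(C1CCS(=O)(=O)CC1)N1CC[C@](c2ccc(C(F)(C(F)(F)F)C(F)(F)F)cc2)(S(=O)(=O)c2ccc(F)cc2)C1` gives 93% remaining

Among the compounds with values here, compound 3 stands at 93% in this assay and lies clearly above compound 1, the only other compound with a single number. Compound 2 has no single number, its repeats being the several entries of compound 2 in this assay, 88%; 100% (2 entries) and these enclose the value of compound 3.

Compound 4 `O=C(N1CC[C@](c2ccc(C(F)(C(F)(F)F)C(F)(F)F)cc2)(S(=O)(=O)c2ccc(F)cc2)C1)C1(O)CCS(=O)(=O)CC1` differs from compound 3 by hydroxy in place of hydrogen on a saturated ring carbon and is not yet measured. Within the data shown here, no measured step makes this change. Among the measured compounds shown here, the one measured step, a number 13 percentage points higher from compound 1 to compound 3 (beyond the scatter), brought in the 1,1-dioxothian-4-yl group that compound 4 keeps, and it bears only indirectly. Compound 3 at 93% also leaves little room for any rise. No change beyond the scatter is expected, the estimated step being a number 3 percentage points lower from compound 3 to compound 4 (within the scatter) in this series. The estimate for compound 4 is 90% within an expected range of 78% to 100% in this assay once tested.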

Compound 4, percent of the compound remaining: 100%
The estimate for compound 4 lay 10 percentage points below the measured number; measured number inside the range.
By their numbers in this assay, from the lowest: compound 1; then compounds 3 and 4 (each within the scatter of the next).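

In this assay, hydroxy on this saturated ring carbon, three ring bonds from the ring sulfur, is tolerated, the step being a number 7 percentage points higher from compound 3 to compound 4 (within the scatter). The 4-hydroxy-1,1-dioxothian-4-yl group also keeps the amide clear of the 4-carboxy-1-methylcyclohexyl amide, the step being a number 20 percentage points higher from compound 1 to compound 4 (beyond the scatter). Repeat entries for a single compound in this series spread about as widely as the gap here, so compound 3 and compound 4 cannot be told apart in this read-out: the several entries of compound 2 in this assay, 88%; 100% (2 entries)

Open, from the compounds shown here alone, is whether an amine, a methoxy group or a fluorine on the same ring carbon would hold the number as hydroxy does. Also open, going by these compounds, is what hydroxy would do on a ring carbon of the acid-bearing group of compound 1, which gives 80% and so leaves more room for a rise.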